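Carbonyl substituent series: the step from compound 3 to compound 4

The compounds below may be only part of what the source reports. "The series", "measured", "known", "first", "only" and "open" are said of these compounds alone.

Compound 3 `O=C(C1CCCCO1)N1CCc2nc(C#Cc3ccccc3)sc2C1` gives 320 nM in an assay on HEK293 cells for positive allosteric modulation of metabotropic glutamate receptor 5 (Homo sapiens), read by FLIPR, with a stated time of 1 h (on this read-out lower numbers stand for an effect already at smaller amounts and higher numbers for an effect only at larger amounts of compound), the highest number of the three measured. Compound 1 `CC1CC1C(=O)N1CCc2nc(C#Cc3ccccc3)sc2C1` gives 9.4 nM and compound 2 `O=C(C1CCC(F)(F)CC1)N1CCc2nc(C#Cc3ccccc3)sc2C1` gives 70 nM. The steps of a 34-fold higher number from compound 1 to compound 3 (1.53 log units; beyond the scatter) and a 4.6-fold higher number from compound 2 to compound 3 (0.66 log units; beyond the scatter) show that exchanging the group on the carbonyl carbon moves the number by modest to large amounts. Compound 4 `O=C(N1CCC(F)CC1)N1CCc2nc(C#Cc3ccccc3)sc2C1` carries the change (4-fluoropiperidin-1-yl in place of oxan-2-yl on a carbonyl carbon). Among the measured compounds shown here, no measured step covers this exchange directly; the nearest precedent is compound 2, whose 4,4-difluorocyclohexyl at the same place gave 70 nM. A step back towards that level is therefore expected, of the size a 3.2-fold lower number from compound 3 to compound 4 (0.51 log units; beyond the scatter), with considerable uncertainty. The estimate for compound 4 is 100 nM, range 25 nM to 400 nM.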

Compound 4, half-maximal effective concentration: 74 nM
Compound 4: middle estimate off by 1.4-fold (0.13 log units), on the high side; the range from low to high includes it.
By their numbers in this assay, from the lowest: compound 1; then compounds 2 and 4 (each within the scatter of the next); then compound 3.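

Exchanging oxan-2-yl for 4-fluoropiperidin-1-yl on the carbonyl carbon lowers the number in this assay (a 4.3-fold lower number from compound 3 to compound 4 (0.64 log units; beyond the scatter)), so a ring joined through its nitrogen is accepted at this place. The 4,4-difluorocyclohexyl and 4-fluoropiperidin-1-yl groups cannot be told apart (a 1.1-fold higher number from compound 2 to compound 4 (0.02 log units; within the scatter)). The small 2-methylcyclopropyl keeps the lowest number (a 7.9-fold higher number from compound 1 to compound 4 (0.90 log units; beyond the scatter)).

No measurement shown accounts for these differences. Open, on these data alone, is whether unsubstituted piperidin-1-yl or morpholin-4-yl on the carbonyl carbon would reach the level of compound 1.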